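The source may report more compounds than this note shows. Statements on the series, on what has been measured and on what is new or still open speak of the compounds shown alone.

Measured compounds:
Compound 1, `O=S(=O)(NCCCNCc1ccccc1)c1cc(C(F)(F)F)cc(C(F)(F)F)c1`: in a functional assay on A2780 cells (Homo sapiens) for inhibition, read by MTT assay, with a stated time of 72 h (on this read-out higher numbers stand for weaker inhibition of growth and lower numbers for stronger inhibition of growth), compound 1 gives 4900 nM.
Compound 2, `O=S(=O)(NCCCNCc1ccc(-c2ccccc2)cc1)c1cc(C(F)(F)F)cc(C(F)(F)F)c1`: in this assay compound 2 gives 2600 nM.

Among the measured compounds shown here, compound 2 sits within the usual scatter of compound 1, the only other measured compound, as the step of a 1.9-fold lower number from compound 1 to compound 2 (0.28 log units; within the scatter) shows; the two numbers cannot be told apart with confidence. Compound 3, `O=S(=O)(NCCCNCc1ccc(Cl)cc1)c1cc(C(F)(F)F)cc(C(F)(F)F)c1`, differs from compound 2 by a single change: chloro in place of phenyl on an aromatic carbon. For the measured compounds named here, the one measured step that bears on this position, a 1.9-fold lower number from compound 1 to compound 2 (0.28 log units; within the scatter), was within the scatter, so adding a phenyl at this spot did little. Swapping that phenyl for a chloro has no direct precedent among the measured compounds, and nothing here points to a large move in either direction. The number for compound 3 in this assay is therefore expected to stay close to that of compound 2, with an expected step of a 1.3-fold higher number from compound 2 to compound 3 (0.13 log units; within the scatter). The estimate for compound 3 is 3500 nM, with a range from 1500 nM to 8000 nM.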

Compound 3, concentration for 50% growth inhibition: 1800 nM
Compound 3: middle estimate off by 1.9-fold (0.29 log units), on the high side; measured number inside the range.
By their numbers in this assay, from the lowest: compounds 3, 2 and 1 (each within the scatter of the next, the first and the last beyond it).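

Chloro in place of hydrogen gives the first step at this position that lies beyond the scatter in this assay, though only a modest one (with a 2.7-fold lower number from compound 1 to compound 3 (0.43 log units; beyond the scatter)). Chloro and phenyl, by contrast, cannot be told apart (with a 1.4-fold lower number from compound 2 to compound 3 (0.16 log units; within the scatter)), even though one brings a single heavy atom and the other brings six, so this position accepts both sizes here without a clear difference in the number. Nothing available explains why chloro differs from hydrogen in this result.

From the compounds shown here alone, it remains open whether the change is particular to chloro or would also appear with a fluoro, a methoxy or an amine at this position. How the number would respond to a longer chain in the shared core is also unknown.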